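The source may hold more compounds than are shown below. What is called first, only, known or untested is meant among the compounds shown, and "the series" means these compounds.

Compound 3 `Cc1ccccc1OS(=O)(=O)c1ccc(NC(=O)NCCCCl)cc1` is one of three close relatives tested in a functional assay on M21 cells (Homo sapiens) for cytotoxicity, read by sulforhodamine B assay, with a stated time of 48 h (on this read-out higher numbers stand for weaker inhibition and lower numbers for stronger inhibition), where compound 3 gives 25000 nM. Compound 1 `CCCc1ccccc1OS(=O)(=O)c1cccc(NC(=O)NCCCCl)c1` carries a 2-propylphenyl on the oxygen and differs from compound 3 in a second place as well; in this assay compound 1 gives 15000 nM, and the gap between compound 1 and compound 3 lies within the scatter. Compound 2 `O=C(NCCCCl)Nc1cccc(S(=O)(=O)Oc2ccc(O)cc2)c1` gives 49000 nM in this assay, again within the scatter of compound 3. Going by the values given here, the only single change measured here is a 3.3-fold higher number from compound 1 to compound 2 (0.51 log units; beyond the scatter), which swaps the whole aryl group on the oxygen and does not speak to a small change on the side chain.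

Compound 4 `CCc1ccccc1OS(=O)(=O)c1ccc(NC(=O)NCCCCl)cc1` differs from compound 3 by methyl in place of hydrogen on a saturated chain carbon bound to an aromatic carbon. Nothing measured here isolates a methyl-to-ethyl change, and compound 1 with its longer propyl chain sits within the scatter of compound 3, so no step beyond the scatter is expected: a 1.3-fold lower number from compound 3 to compound 4 (0.10 log units; within the scatter). Compound 4 is therefore estimated at 20000 nM in this assay, with a range from 8000 nM to 50000 nM.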

Compound 4, half-maximal inhibitory concentration: 15000 nM
Estimate against measurement, compound 4: 1.3-fold (0.12 log units) above, within the range that was stated.
By their numbers in this assay, from the lowest: compounds 1, 4, 3 and 2 (each within the scatter of the next, the first and the last beyond it).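

In this assay, going from 2-methylphenyl to 2-ethylphenyl gives a 1.7-fold lower number from compound 3 to compound 4 (0.22 log units; within the scatter) and so adds a methyl on a saturated chain carbon bound to an aromatic carbon without a change that can be told apart from the scatter. Going by these compounds alone, this is the first small single change at this group: the only earlier step, a 3.3-fold higher number from compound 1 to compound 2 (0.51 log units; beyond the scatter), replaced the whole aryl group on the oxygen, so it could not show that this small extension of the chain is tolerated in this assay. No measurement shown here offers an explanation for this result.

On these data alone, whether the chain can grow further on the core of compound 3 remains open, as a propyl or longer chain there would test. As far as these compounds go, it is also open how an amine or a carboxylic acid at the end of this chain would read.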